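Ester to Methylamide on a Spirocyclic Urea Series

The source may report more compounds than this note shows. Statements on the series, on what has been measured and on what is new or still open speak of the compounds shown alone.

Measured compounds:
Compound 1, `CN1CC2(CCN(C(=O)Nc3cc(F)cc(F)c3)CC2)C1c1ccc(F)cc1`: 410 nM
Compound 2, `CC[C@H](C)[C@H](NC(=O)N1CCC2(CC1)C(=O)N(c1cccc(F)c1)C2c1ccc(Cl)cc1)C(=O)OC`: 45 nM; 872 nM (2 entries)
Compound 3, `CC[C@H](C)[C@H](NC(=O)N1CCC2(CC1)C(=O)N(c1cccc(F)c1)C2c1ccc(Cl)cc1)C(=O)OC(C)C`: 45 nM

All three were tested in an assay on HEK293 cells for inhibition of Voltage-dependent T-type calcium channel subunit alpha-1H (Homo sapiens), read by patch clamp, using a membrane potential dye; on this read-out lower numbers stand for stronger inhibition and higher numbers for weaker inhibition. Compound 3 stands at the lower of the two single numbers; compound 1 sits higher, and the gap between them lies beyond the usual scatter. Compound 2 cannot be placed on one number because the several entries of compound 2 in this assay, 45 nM; 872 nM (2 entries) shows entries that lie far apart, and the lower of them coincides with the value of compound 3, so the ester size from methyl to isopropyl does not separate these two on what is shown.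

The next compound, compound 4, `CC[C@H](C)[C@H](NC(=O)N1CCC2(CC1)C(=O)N(c1cccc(F)c1)C2c1ccc(Cl)cc1)C(=O)NC`, differs from compound 3 in one place: methylamino in place of isopropoxy on a carbonyl carbon. Among the compounds with values here, no pair of measured compounds spans this kind of change, so the size of the step has to be guessed from the ester variation alone, which gave no movement beyond the scatter. The step of a 1.8-fold higher number from compound 3 to compound 4 (0.25 log units; within the scatter) is therefore expected to be small, with a slight lean toward weaker inhibition. Compound 4 is estimated at 80 nM, with a likely range from 25 nM to 300 nM.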

Compound 4, half-maximal inhibitory concentration: 182 nM
Compound 4: middle estimate off by 2.3-fold (0.36 log units), on the low side, within the range that was stated.
By their numbers in this assay, from the lowest: compound 3; then compound 4; then compound 1.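

Replacing isopropoxy with methylamino on a carbonyl carbon gives a 4.0-fold higher number from compound 3 to compound 4 (0.61 log units; beyond the scatter), so in this assay this place responds to an exchange of ester for amide, something the ester variation alone could not show. The step is modest and rests on a single pair, so it describes this methylamide against this isopropyl ester and sets no general rule for amides in the series. Compound 4, at 182 nM, also lies inside the spread of the methyl ester, which means that no step from that ester can be read and that the single clean comparison remains the one with the isopropyl ester, as the entries for the methyl ester show: the several entries of compound 2 in this assay, 45 nM; 872 nM (2 entries)

The compounds shown leave open whether the step follows from the entering nitrogen and its hydrogen or from the loss of heavy atoms, and an isopropylamino group on the same carbonyl carbon would separate the two. Going by these compounds, how a dimethylamino group, a primary carboxamide or a carboxylic acid would read at this place also stays open.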